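Fluoro to Chloro on the Sulfonamide Aryl Ring

This account rests on a few compounds, and the source may have more. Where it says the series, first, only, none or still open, it means among the compounds named here.

Compound 1 `COc1ccc(-c2cn(C/C=C3\OC(=O)C(OCc4ccccc4)=C3OCc3ccccc3)nn2)cc1`: in this assay it reads > 100000 nM, a limit of the assay.
Compound 2 `O=C1O/C(=C\Cn2cc(-c3cc(F)cc(F)c3)nn2)C(OCc2ccccc2)=C1OCc1ccccc1`: in this assay it reads > 100000 nM, a limit of the assay.
Compound 3 `O=C1O[C@H]([C@@H](O)Cn2cc(CNS(=O)(=O)c3ccc(F)cc3)nn2)C(OCc2ccccc2)=C1OCc1ccccc1`: in this assay it reads 30 nM.

The read-out is an ADME assay on HFF cells (Homo sapiens) for cytotoxicity, read by MTT assay, with a stated time of 72 h; on this read-out lower numbers stand for stronger inhibition and higher numbers for weaker inhibition. Within the data shown here, compound 3 stands as the only value that is a true number; compound 1 and compound 2 sit at the limit of > 100000 nM in this assay, at which 2 of the 3 values shown sit. Among the measured compounds shown here, the single measured step, a step that the two limits leave unreadable from compound 1 to compound 2, runs between two limits and therefore gives no readable size. Compound 4 `O=C1O[C@H]([C@@H](O)Cn2cc(CNS(=O)(=O)c3ccc(Cl)cc3)nn2)C(OCc2ccccc2)=C1OCc1ccccc1` is built from compound 3 by chloro in place of fluoro on an aromatic carbon. For the measured compounds named here, no measured step touches this change: the one step that exists involves a different part of a different core and is unreadable in any case, so nothing here argues for a move in either direction. The expectation is therefore a step of about no change at the digits printed from compound 3 to compound 4 (within the scatter) from compound 3 to compound 4, which is within the usual scatter. Compound 4 is accordingly estimated at 30 nM, with a range from 10 nM to 90 nM.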

Compound 4, half-maximal inhibitory concentration: 20 nM
Beside the measured number, compound 4's estimate is 1.5-fold (0.18 log units) above it; measured number inside the range.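

In this assay, chloro in place of fluoro on the sulfonyl aryl ring gives a 1.5-fold lower number from compound 3 to compound 4 (0.18 log units; within the scatter), the only step among the compounds shown that can be read, as the one earlier step runs between two limits. The result shows that, for this pair, the 4-fluorophenyl and 4-chlorophenyl versions cannot be told apart on this read-out, so this one halogen exchange at this place, para to a large group, leaves the reading where it was within the usual scatter. Nothing measured here bears on why the two values sit so close, and one pair of halogens gives no rule for other groups at the same place.

The compounds shown leave open whether a group of a different kind at that ring position, such as an amine, a carboxylic acid or a longer chain, would also leave the reading unmoved. They also leave open which structural feature separates compound 3 and compound 4 from compound 1 and compound 2, since those two differ from compound 3 in more than one place.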